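Three Level Analogues and a Chain-Bearing Fourth

A few compounds are considered here, and "the series" means these few. Any claim that something is new, unique, unknown or untested is made for them only; others in the source may bear on it.

Compound 1: `COc1cccc2cc(-c3ccccc3)c(O)nc12` — 10000 nM
Compound 2: `COc1ccc2cc(-c3ccccc3)c(O)nc2c1` — 10000 nM
Compound 3: `COc1ccc(-c2cc3c(OC)cc(OC)cc3n(C)c2=O)cc1` — 10000 nM

The three compounds above were tested in a functional assay on J82 cells (Homo sapiens) for cytotoxicity, read by colorimetric assay and MTT assay; on this read-out lower numbers stand for stronger inhibition and higher numbers for weaker inhibition. On that read-out compound 1 gives 10000 nM, compound 2 gives 10000 nM, and compound 3 gives 10000 nM. Compound 3 therefore stands level with compounds 1 and 2 at the digits shown: its nearest neighbour is compound 1 and its furthest is compound 2, and in neither case is there a change beyond the scatter of repeated measurements. For the measured compounds named here, no pair among the three compounds differs in only one place, so no single step between measured compounds is available, and the three values together say only that the set is flat.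

The unmeasured compound 4 is `COc1ccc(-c2cc3c(OC)cc(OC)cc3n(CCCC#N)c2=O)cc1`. It is built from compound 3 by the change (2-cyanoethyl in place of hydrogen on a saturated chain carbon bound to an aromatic nitrogen). Going by the values given here, no measured pair shows the effect of this change, and the flat set gives no direction to lean toward. The expected step in this assay is therefore one of no size beyond the scatter, that is no change at the digits printed from compound 3 to compound 4 (within the scatter). Compound 4 is estimated at 10000 nM, with a range from 5000 nM to 20000 nM.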

Compound 4, half-maximal inhibitory concentration: 10000 nM
Beside the measured number, compound 4's estimate shows no gap at the digits printed; measured number inside the range.
By their numbers in this assay, from the lowest: compounds 1, 2, 3 and 4 (each within the scatter of the next).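

In this assay, for the compounds shown here, the set now has its first step that can be read, no change at the digits printed from compound 3 to compound 4 (within the scatter), where the earlier compounds offered no pair differing in one place. The step concerns 2-cyanoethyl in place of hydrogen on a saturated chain carbon bound to an aromatic nitrogen, a difference that, cut one bond further out, reads as methyl to 3-cyanopropyl; this place therefore takes a chain ending in a nitrile with nothing beyond the scatter in this read-out. Nothing available here speaks to why the number stays level across this change.

On these data alone, what remains open is whether any group at this place separates from the level of compound 3 and compound 4, since a single nitrile-bearing chain says nothing about an amine, a carboxylic acid or a longer chain there. Open too, as far as these compounds go, is whether a change elsewhere on the shared core of these two compounds, such as a hydroxyl in place of one of its methoxy groups, would give a different number in this assay.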